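Cytotoxicity notes: methoxycarbonyl in place of methyl

The source may report more compounds than this note shows. Statements on the series, on what has been measured and on what is new or still open speak of the compounds shown alone.

Compound 2 `Cc1ccc(NC(=O)CSc2snnc2-c2ccccc2)c(Br)c1` stands, like everything else in this set, at a limit of the assay. In an ADME assay on MT4 cells (Homo sapiens) for cytotoxicity (on this read-out higher numbers stand for lower toxicity in this test and lower numbers for higher toxicity in this test), compound 2 gives > 297000 nM, a limit and not a number. Compound 1 `Cc1ccc(NC(=O)CSc2snnc2-c2ccc(Cl)cc2Cl)c(Br)c1` gives > 255000 nM, likewise a limit. Compound 3 `O=C(CSc1snnc1-c1ccccc1)Nc1ccccc1Cl` gives > 345000 nM, again a limit. The two measured steps, a step that the two limits leave unreadable from compound 1 to compound 2 and a step that the two limits leave unreadable from compound 2 to compound 3, are therefore unreadable in size; none of them involves a methoxycarbonyl. Compound 4 `COC(=O)c1ccc(NC(=O)CSc2snnc2-c2ccccc2)c(Br)c1` changes (methoxycarbonyl in place of methyl on an aromatic carbon). With every value at a limit, no step beyond the scatter is expected, and the step from compound 2 to compound 4 is estimated as a step that the limit leaves unreadable from compound 2 to compound 4. Compound 4 is expected to give 300000 nM, within 120000 nM to 600000 nM, most likely reported as a limit again.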

Compound 4, half-maximal cytotoxic concentration: > 269000 nM
Compound 4 was reported as a limit (the forecaster's own chance of this, stated with the estimate: 85%); the middle value does not contradict the limit.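

Within the data shown here, compound 2 and compound 4 are both reported as limits, so no step between them can be read. The compounds shown leave open what size of effect, if any, methoxycarbonyl in place of methyl has on this read-out.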